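Replacing Fluorine with Methyl: Compound 1 to Compound 3

This account rests on a few compounds, and the source may have more. Where it says the series, first, only, none or still open, it means among the compounds named here.

In a functional assay on SW480 cells (Homo sapiens) for antiproliferative activity, with a stated time of 72 h (on this read-out lower numbers stand for stronger inhibition and higher numbers for weaker inhibition), compound 1 (`O=C(COc1ccc(CNC2CC=C(c3c[nH]c4cccc(F)c34)CC2)c(F)c1)NO`) gives 189 nM and compound 2 (`Cc1[nH]c2ccccc2c1C1=CCC(NCc2ccc(OCC(=O)NO)cc2)CC1`) gives 367 nM. These two values lie within the usual scatter of each other, so compound 1 cannot be separated from compound 2 on these numbers. Compound 3 (`Cc1ccc2[nH]cc(C3=CCC(NCc4ccc(OCC(=O)NO)cc4F)CC3)c2c1`) carries 5-methyl-1H-indol-3-yl in place of 4-fluoro-1H-indol-3-yl on a double-bonded ring carbon. Among the measured compounds shown here, no measured pair differs in only one place, so the expectation rests on two values alone. Compound 2, which also bears a methyl group, gives 367 nM, and this value stays within the scatter of compound 1. In this assay, a small move towards a higher number is therefore expected, no larger than the scatter: a 1.3-fold higher number from compound 1 to compound 3 (0.12 log units; within the scatter). For compound 3 the estimated value is 250 nM, with an expected range of 100 nM to 650 nM.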

Compound 3, half-maximal inhibitory concentration: 2780 nM
Estimate against measurement, compound 3: 11-fold (1.05 log units) below, outside the stated range (above it).
By their numbers in this assay, from the lowest: compounds 1 and 2 (each within the scatter of the next); then compound 3.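

In this assay, 5-methyl-1H-indol-3-yl in place of 4-fluoro-1H-indol-3-yl on a double-bonded ring carbon gives a 15-fold higher number from compound 1 to compound 3 (1.17 log units; beyond the scatter), a large step beyond the scatter. This is the first step among these compounds that isolates this position, and it shows that the read-out responds strongly to the change there, even though both groups have the same count of heavy atoms, the same rings and the same hydrogen-bond donor count. Nothing measured here accounts for the size of this step.

The change alters both the substituent on the indole and where it sits, so the compounds shown cannot separate these two contributions. Going by these compounds, how 4-methyl-1H-indol-3-yl or 5-fluoro-1H-indol-3-yl would read at this position remains open.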